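Para-bromo substitution on a phenyl ketone hydroxamate

The compounds below may be only part of what the source reports. "The series", "measured", "known", "first", "only" and "open" are said of these compounds alone.

Compound 1 `O=C(CCCCCCCC(=O)c1ccccc1)NO` carries a phenyl ketone at one end of its chain and a hydroxamic acid at the other. Within the data shown here, in an assay on isolated protein for inhibition of histone deacetylase 8 (Homo sapiens) (a higher number here means a weaker inhibitor, a lower number a stronger inhibitor), compound 1 gives 65 nM, the lower of the two numbers so far. Among the measured compounds shown here, its only measured neighbour is compound 2 `COc1ccccc1C(=O)CCCCCCCC(=O)NO`, which in this assay gives 95 nM; the step of a 1.5-fold higher number from compound 1 to compound 2 (0.16 log units; within the scatter) shows that a methoxy in place of hydrogen on an aromatic carbon left the number essentially unchanged. Compound 3 `O=C(CCCCCCCC(=O)c1ccc(Br)cc1)NO` differs from compound 1 by bromo in place of hydrogen on an aromatic carbon. For the measured compounds named here, the one relevant precedent, the step from compound 1 to compound 2, is small, so a small change is expected here too, with no clear direction beyond the scatter. For compound 3 the expected value is 60 nM, with a range from 28 nM to 130 nM, an expected step of a 1.1-fold lower number from compound 1 to compound 3 (0.03 log units; within the scatter).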

Compound 3, half-maximal inhibitory concentration: 45 nM
The estimate for compound 3 lay 1.3-fold (0.12 log units) above the measured number; the measured number falls inside the stated range.
By their numbers in this assay, from the lowest: compounds 3, 1 and 2 (each within the scatter of the next, the first and the last beyond it).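

In this assay, the step of a 1.4-fold lower number from compound 1 to compound 3 (0.16 log units; within the scatter) shows that bromo can stand on an aromatic carbon para to a large group while the number stays within the scatter. Among these compounds, compound 2 carries its methoxy at a different place on the ring, so this is the only reading for this place, and with the step of a 1.5-fold higher number from compound 1 to compound 2 (0.16 log units; within the scatter) neither substitution on the ring of compound 1 moves the number beyond the scatter. No supporting evidence bears on why this step is so small.

The compounds shown leave open whether any group at this place moves the number beyond the scatter, for instance an amine or a carboxylic acid. They also leave open whether bromo at another place on the ring would give the same reading.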